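The compounds below may be only part of what the source reports. "The series", "measured", "known", "first", "only" and "open" are said of these compounds alone.

Compound 1 `CC(=O)Oc1cccc2cc(-c3cc(Br)cs3)c(=O)oc12` in a functional assay on isolated protein for antagonist activity at adenosine receptor A2b (Homo sapiens) (on this read-out higher numbers stand for weaker inhibition and lower numbers for stronger inhibition), gives > 30000 nM, a limit of the assay.
Compound 2 `O=c1oc2c(O)cccc2cc1-c1cccs1` gives > 30000 nM, also a limit.
Compound 3 `O=c1oc2c(O)cccc2cc1-c1ccsc1` gives > 30000 nM, again a limit.

Compound 3 thus stands at the limit, as do the other two compounds (the limit of > 30000 nM in this assay, at which 3 of the 3 values shown sit). Within the data shown here, the single step among the measured compounds, a step that the two limits leave unreadable from compound 2 to compound 3, is unreadable, since both of its ends are limits. Compound 4 `O=c1oc2c(O)cccc2cc1-c1cc(Br)cs1` differs from compound 3 by 4-bromothiophen-2-yl in place of thiophen-3-yl on an aromatic carbon. Among the measured compounds shown here, compound 1 carries the same 4-bromothiophen-2-yl group and also sits at the limit, so no measured step gives a readable size for this change. Compound 4 is therefore expected to stay at the limit. The expected step that the limit leaves unreadable from compound 3 to compound 4 is none beyond the scatter. Compound 4 is estimated at 40000 nM, within a range from 15000 nM to 200000 nM.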

Compound 4, inhibition constant: > 30000 nM
Compound 4: a limit, no number; the forecaster's own chance of this, stated with the estimate: 85%; the middle value is on the limit's open side.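

Compound 4 also sits at a limit, so its steps from compound 1, compound 2 and compound 3 cannot be read: the limit of > 30000 nM in this assay, at which 4 of the 4 values shown sit.

The compounds shown leave open whether any of these changes alters inhibition in this assay.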